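Debromination of the benzyl group in a cytotoxicity series

The source may report more compounds than this note shows. Statements on the series, on what has been measured and on what is new or still open speak of the compounds shown alone.

Compound 1 `O=C1N(Cc2ccccc2Br)c2cccn2S(=O)(=O)N1Cc1cccc(F)c1` has been tested in an ADME assay on MT4 cells (Homo sapiens) for cytotoxicity, read by MTT assay, with a stated time of 5 days; on this read-out lower numbers stand for higher toxicity in this test and higher numbers for lower toxicity in this test. In this assay compound 1 gives only a limit, > 269000 nM. Compound 2 `N#Cc1ccccc1CN1C(=O)N(Cc2ccccc2)S(=O)(=O)n2cccc21` likewise gives only a limit in this assay, > 318000 nM. Compound 3 `N#Cc1cccc(CN2C(=O)N(Cc3ccccc3)S(=O)(=O)n3cccc32)c1` also gives only a limit, > 318000 nM. Among the compounds with values here, the single step between measured compounds, a step that the two limits leave unreadable from compound 2 to compound 3, cannot be read, as both of its ends sit at the limit of > 318000 nM in this assay, at which 2 of the 3 values shown sit. Compound 1 stands at the limit of > 269000 nM in this assay, at which 1 of the 3 values shown sits, and so it cannot be set apart from the other two: none of the three shows measurable toxicity in this assay.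

Compound 4 `O=C1N(Cc2ccccc2)c2cccn2S(=O)(=O)N1Cc1cccc(F)c1` differs from compound 1 by hydrogen in place of bromo on an aromatic carbon. No measured step covers the removal of bromo, and the one step shown is unreadable. With every value shown being a limit, no change beyond the scatter is expected, and a limit is the most likely outcome for compound 4. The step that the limit leaves unreadable from compound 1 to compound 4 is estimated to stay within the scatter. Compound 4 is expected at 300000 nM, within a range from 150000 nM to 600000 nM.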

Compound 4, half-maximal cytotoxic concentration: > 288000 nM
Compound 4 ended at the assay's limit (the forecaster's own chance of this, stated with the estimate: 85%); the middle value lies beyond the limit too.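

Compound 1 and compound 4 both give only limits, so the step between them, hydrogen in place of bromo on an aromatic carbon, cannot be read. The compounds shown leave open whether any member of this series reaches a measurable half-maximal cytotoxic concentration in this assay.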